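The source may report more compounds than this note shows. Statements on the series, on what has been measured and on what is new or still open speak of the compounds shown alone.

In a functional assay on HL-60 cells (Homo sapiens) for antiproliferative activity, read by MTT assay (a lower number here means a stronger inhibitor, a higher number a weaker inhibitor), compound 2 (`C=CC[C@@H]1O[C@H](COCc2ccccc2)[C@@H](OCc2ccccc2)[C@H](OCc2ccccc2)[C@H]1O`) gives 15100 nM, within the scatter of both other measured compounds: compound 1 (`C=C[C@@H]1O[C@H](COCc2ccccc2)[C@@H](OCc2ccccc2)[C@H](OCc2ccccc2)[C@H]1O`) gives 11800 nM and compound 3 (`C=CC[C@@H]1O[C@H](COCc2ccccc2)[C@@H](OCc2ccccc2)[C@H](OCc2ccccc2)[C@H]1OC(C)=O`) gives 26900 nM. Compound 4 (`CCC[C@@H]1O[C@H](COCc2ccccc2)[C@@H](OCc2ccccc2)[C@H](OCc2ccccc2)[C@H]1O`) differs from compound 2 by ethyl in place of vinyl on a saturated chain carbon bound to a saturated ring carbon, which also reads allyl to propyl. The step closest in kind is a 1.3-fold higher number from compound 1 to compound 2 (0.11 log units; within the scatter), which also changes the chain on the saturated ring carbon. The other step, a 1.8-fold higher number from compound 2 to compound 3 (0.25 log units; within the scatter), lies elsewhere, on an oxygen on a saturated carbon. Within the data shown here, no measured pair tests this exact change. Neither step leaves the scatter, so no step beyond the scatter is expected in this assay. The expected step is a 1.1-fold higher number from compound 2 to compound 4 (0.03 log units; within the scatter). For compound 4 the estimated value is 16000 nM, with an expected range of 8000 nM to 32000 nM.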

Compound 4, half-maximal inhibitory concentration: 11700 nM
Compound 4: middle estimate off by 1.4-fold (0.14 log units), on the high side; low and high end bracket the measured number.
By their numbers in this assay, from the lowest: compounds 4, 1, 2 and 3 (each within the scatter of the next, the first and the last beyond it).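

Allyl to propyl in this assay gives (a 1.3-fold lower number from compound 2 to compound 4 (0.11 log units; within the scatter)), and vinyl to propyl gives (a 1.0-fold lower number from compound 1 to compound 4 (0.00 log units; within the scatter)). With the double bond gone from the chain, compound 4 stays within the scatter of compound 1 and compound 2, so in these three compounds this chain tolerates vinyl, allyl and propyl alike. No measurement at hand gives a reason for this. On these data alone, whether a longer chain or an amine in place of propyl on a saturated ring carbon would leave the scatter remains open.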